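A few compounds are considered here, and "the series" means these few. Any claim that something is new, unique, unknown or untested is made for them only; others in the source may bear on it.

Measured compounds:
- compound 1, `CC(C#CCn1ccnc1)N1CCCC1=O`, gives 45 mg/kg
- compound 2, `Cc1cncn1CC#CC(C)N1CCCC1=O`, gives 25.4 mg/kg
- compound 3, `O=C1OCCN1CC#CCn1ccnc1`, gives > 100 mg/kg, which is a limit of the assay and not a number

The read-out throughout is a functional assay on the whole organism for antagonist activity, with Mus musculus as the target; a lower number here means that less compound is needed, a higher number that more compound is needed for the effect. Compound 1 and compound 2 share a core and differ by methyl in place of hydrogen on an aromatic carbon. That change made a 1.8-fold lower number from compound 1 to compound 2 (0.25 log units; within the scatter), so the two values lie within the usual scatter of each other and no order between them is claimed.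

Compound 3 carries a different core; the difference between the core of compound 1 and the core of compound 3 is not broken down here. For compound 3 this assay gave only a limit, (the limit of > 100 mg/kg in this assay, at which 1 of the 3 values shown sits).

Compound 4, `Cc1cncn1CC#CCN1CCOC1=O`, has not yet been measured. It stands to compound 3 as compound 2 stands to compound 1: the change is methyl in place of hydrogen on an aromatic carbon, and the place is described in the same words for both pairs, so it is the same change. In this assay the earlier instance of the change stayed within the scatter, and compound 3 itself gave only a limit, so compound 4 is expected to come out close to that limit as well. The step expected from compound 3 to compound 4 is a number no higher from compound 3 to compound 4 (the limit leaves the size open), and this rests on the size of a 1.8-fold lower number from compound 1 to compound 2 (0.25 log units; within the scatter). For compound 4 the estimate is 100 mg/kg, with a range from 40 mg/kg to 300 mg/kg, and a substantial chance that this assay again reports only a limit.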

Compound 4, dose for half-maximal effect: > 100 mg/kg
Compound 4 was reported as a limit; the forecaster's own chance of this, stated with the estimate: 65%; the middle value sits exactly at the limit.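

In this assay, going by these compounds alone, compound 3 and compound 4 both ended at a limit of the assay and not at a number, so no step between them can be read: the limit of > 100 mg/kg in this assay, at which 2 of the 4 values shown sit. The compounds shown leave open what number either compound would give in this assay, and whether methyl in place of hydrogen on an aromatic carbon shifts the result on the core of compound 3.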